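This account rests on a few compounds, and the source may have more. Where it says the series, first, only, none or still open, it means among the compounds named here.

Compound 1 `N=C(CS)NC(c1ccccc1)c1ccccc1` and compound 2 `N=C(CS)NC(c1ccccc1)c1ccc(Cl)cc1` share one core; compound 3 `N=C(CS)Nc1ccccc1` has another, and the difference between the two cores is not broken down here. In a functional assay on the whole organism (stomach, strain beagle) for inhibition, with Canis familiaris (Canis lupus familiaris) as the target, with a stated time of 2 h, at a dose of 16 mg/kg (a higher number here means a stronger effect of the compound at the dose given, a lower number a weaker effect), compound 1 gives 82% and compound 2 gives 87%; the step of a number 5 percentage points higher from compound 1 to compound 2 (within the scatter) goes with chloro in place of hydrogen on an aromatic carbon. Compound 3 gives 0%, far below both. Compound 4 `N=C(CS)Nc1cccc(Cl)c1` arises from compound 3 by chloro in place of hydrogen on an aromatic carbon, the same kind of change as from compound 1 to compound 2, though there the place is para to a large group and here meta to a group of 5 heavy atoms. Since on the core of compound 1 the chloro moved the number only within the scatter, for compound 4 a step of a number 5 percentage points higher from compound 3 to compound 4 (within the scatter) is expected, resting on compound 3 at 0% and on a number 5 percentage points higher from compound 1 to compound 2 (within the scatter). The estimate for compound 4 is 5%, between 0% and 20%.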

Compound 4, a percentage reported as inhibition, in the whole organism at one dose (the size of the read-out at that dose, not a potency): 16%
The estimate for compound 4 lay 11 percentage points below the measured number; the measured number falls inside the stated range.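

In this assay, chloro in place of hydrogen on an aromatic carbon gives a number 16 percentage points higher from compound 3 to compound 4 (beyond the scatter), a modest step at one dose and not a measure of potency. Set beside the earlier step, the change shows no difference between the two cores: the same change on two cores in this assay, a number 5 percentage points higher (within the scatter) from compound 1 to compound 2 and a number 16 percentage points higher (beyond the scatter) from compound 3 to compound 4, 11 percentage points apart, within the scatter of two such steps. For the compounds shown here, this shows only that these two pairs cannot be told apart; it does not show that the step carries over to other cores, and the chloro in compound 4 stands meta to a group of 5 heavy atoms, a place not shared with compound 2.

Open, going by these compounds, is how a methoxy group, an amine or a carboxylic acid would read at that place. Also open, on these data alone, is whether chloro elsewhere on the ring of compound 3 gives a similar step.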